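Replacing a Chlorophenyl Amide with Cyclobutyl: an Expectation

This account rests on a few compounds, and the source may have more. Where it says the series, first, only, none or still open, it means among the compounds named here.

Compound 1 `O=C(c1ccc(Cl)cc1)N1CCN(c2nc(=O)c3cc(C(F)(F)F)cc([N+](=O)[O-])c3s2)CC1` gives in an ADME assay on Vero cells (Chlorocebus sabaeus) for cytotoxicity, read by MTT assay, with a stated time of 72 h (on this read-out higher numbers stand for lower toxicity in this test and lower numbers for higher toxicity in this test), only a limit, > 125000 nM.
Compound 2 `O=C(C1CCCCC1)N1CCN(c2nc(=O)c3cc(C(F)(F)F)cc([N+](=O)[O-])c3s2)CC1` gives in this assay 88700 nM.
Compound 3 `O=C(CC1CCCCC1)N1CCN(c2nc(=O)c3cc(C(F)(F)F)cc([N+](=O)[O-])c3s2)CC1` gives in this assay only a limit, > 125000 nM.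

Compound 1 thus stands at the limit of > 125000 nM in this assay, at which 2 of the 3 values shown sit, and compound 3 stands at that limit too; only compound 2 gives a number. Compound 4 `O=C(C1CCC1)N1CCN(c2nc(=O)c3cc(C(F)(F)F)cc([N+](=O)[O-])c3s2)CC1` differs from compound 1 by cyclobutyl in place of 4-chlorophenyl on a carbonyl carbon. The measured steps that bear on this are an at least 1.4-fold lower number from compound 1 to compound 2 (0.14 log units; that floor lies within the scatter) and a step that the two limits leave unreadable from compound 1 to compound 3, together with an at least 1.4-fold higher number from compound 2 to compound 3 (0.14 log units; that floor lies within the scatter); none of them is readable as a change beyond the scatter. Compound 4 is therefore expected to show no step beyond the scatter, an at least 1.1-fold lower number from compound 1 to compound 4 (0.05 log units; that floor lies within the scatter), with a fair chance of another limit. Compound 4 is estimated at 110000 nM, between 60000 nM and 200000 nM.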

Compound 4, half-maximal cytotoxic concentration: > 125000 nM
Compound 4: no number, only a limit (the forecaster's own chance of this, stated with the estimate: 55%); middle value at least 1.1-fold (0.05 log units) away from the limit.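

For the compounds shown here, with the four-membered cyclobutyl on the carbonyl carbon, compound 4 also gives only a limit, so three different groups at this position now end there: the limit of > 125000 nM in this assay, at which 3 of the 4 values shown sit. The one step that can be read is an at least 1.4-fold higher number from compound 2 to compound 4 (0.14 log units; that floor lies within the scatter), which leaves compound 2 not set apart beyond the scatter, while the steps from compound 1 and from compound 3 to compound 4 cannot be read.

On these data alone, how far compound 1, compound 3 and compound 4 lie past the limit remains open. So does whether an amine, a carboxylic acid or a longer chain on this carbonyl carbon would give a readable number.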